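Tosylate and trifluoromethylphenyl on a shared core

A few compounds are considered here, and "the series" means these few. Any claim that something is new, unique, unknown or untested is made for them only; others in the source may bear on it.

Measured compounds:
compound 1, `C=C1C[C@]23C[C@@]1(O)CC[C@H]2c1ccc(OS(=O)(=O)c2ccc(C)cc2)c(C)c1[C@@H]3Cn1cc(-c2ccc(OC)cc2)nn1`, > 20000 nM in a functional assay on A549 cells (Homo sapiens) for cytotoxicity, read by MTT assay, with a stated time of 4 days; on this read-out higher numbers stand for weaker inhibition and lower numbers for stronger inhibition; compound 2, `C=C1C[C@]23C[C@@]1(O)CC[C@H]2c1cc(Br)c(O)c(C)c1[C@@H]3Cn1cc(-c2ccc(C(F)(F)F)cc2)nn1`, 9280 nM; compound 3, `C=C1C[C@]23C[C@@]1(O)CC[C@H]2c1ccc(O)c(C)c1[C@@H]3Cn1cc(-c2ccc(OC)cc2)nn1`, > 20000 nM.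

Compound 1 gives only a limit in this assay, and that limit is > 20000 nM. Compound 3 also stops at a limit, namely > 20000 nM. Compound 2 gives a number, 9280 nM. Within the data shown here, the one single-point step among them, a step that the two limits leave unreadable from compound 1 to compound 3, cannot be sized, since the limit of > 20000 nM in this assay, at which 2 of the 3 values shown sit, holds both of its ends. Among the measured compounds shown here, compound 2 and compound 3 differ in two places at once, so their values show only that compound 2 reaches a number where compound 3 does not.

Compound 4, `C=C1C[C@]23C[C@@]1(O)CC[C@H]2c1ccc(OS(=O)(=O)c2ccc(C)cc2)c(C)c1[C@@H]3Cn1cc(-c2ccc(C(F)(F)F)cc2)nn1`, comes from compound 1 by trifluoromethyl in place of methoxy on an aromatic carbon. For the measured compounds named here, no measured step isolates this change, and the only numbered value, that of compound 2, carries the same 4-(trifluoromethyl)phenyl group. The step from compound 1 to compound 4 is therefore expected to be an at least 1.4-fold lower number from compound 1 to compound 4 (0.15 log units; that floor lies within the scatter) at most, with a real chance that compound 4 again returns only a limit. Compound 4 is estimated at 14000 nM, within 5000 nM to 40000 nM.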

Compound 4, half-maximal inhibitory concentration: > 20000 nM
Compound 4: a limit, no number; the forecaster's own chance of this, stated with the estimate: 45%; middle value at least 1.4-fold (0.15 log units) away from the limit.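

Compound 4 returns only a limit, as compound 1 does, so no step between compound 1 and compound 4 can be read, because both stop at the same limit: the limit of > 20000 nM in this assay, at which 3 of the 4 values shown sit.

The compounds shown leave open whether trifluoromethyl in place of methoxy shifts the read-out at all.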